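The compounds below may be only part of what the source reports. "The series", "measured", "known", "first", "only" and "open" are said of these compounds alone.

Measured so far:
- compound 1, `CC[C@@H](Nc1c(C#N)c(-c2ccc(-c3cccc(Cl)c3F)cc2)nc2cnccc12)C(N)=O`, in a physicochemical assay for lipophilicity, read by HPLC, at pH 7.5; on this read-out higher numbers stand for higher lipophilicity and lower numbers for lower lipophilicity: 3.1
- compound 2, `CC[C@@H](Nc1c(C#N)c(-c2ccc(-c3cccc(Cl)c3)cc2)nc2cnccc12)C(N)=O`, this assay: 3.1

Among the compounds with values here, compound 2 stands level with compound 1; the only measured step, no change at the digits printed from compound 1 to compound 2 (within the scatter), is within the scatter, so the pair gives no direction. Compound 3 is `CC[C@@H](Nc1c(C#N)c(-c2ccc(-c3ccccc3F)cc2)nc2cnccc12)C(N)=O`, not yet measured in this assay. It differs from compound 2 in one place: 2-fluorophenyl in place of 3-chlorophenyl on an aromatic carbon.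

The measured step bears on this change only in part. It shows that taking fluoro off an aromatic carbon left the read-out unchanged in the step from compound 1 to compound 2, which suggests that the fluorine entering with the 2-fluorophenyl should matter little. Within the data shown here, no measured step covers the exchange of 3-chlorophenyl for a group without chlorine, so that side of the change is without precedent here. The expectation for a number 0.40 log units lower from compound 2 to compound 3 (beyond the scatter) therefore rests on a single comparison and carries a wide range; on balance a small downward step is expected, though one within the scatter is not excluded. For compound 3 the estimate in this assay is 2.7, between 2.2 and 3.2.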

Compound 3, distribution coefficient: 2.7
Compound 3: middle estimate and measured number agree at the digits printed, within the range that was stated.
By their numbers in this assay, from the lowest: compound 3; then compounds 1 and 2 (each within the scatter of the next).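

In this assay, within the data shown here, the chloro on this ring is the first substituent whose removal moves the read-out beyond the scatter: hydrogen in its place gives a number 0.40 log units lower from compound 1 to compound 3 (beyond the scatter) in this series, whereas hydrogen in place of fluoro gave no change at the digits printed from compound 1 to compound 2 (within the scatter) on the same ring. The exchange of 3-chlorophenyl for 2-fluorophenyl gives a number 0.40 log units lower from compound 2 to compound 3 (beyond the scatter) and so matches the removal of chloro in size at the digits printed, which places the whole of the measured change in these three compounds on the loss of chloro rather than on the presence of fluoro. No measurement available here bears on why the number moves at this position.

Open, going by these compounds, is how a phenyl carrying neither halogen would read, and whether bromo, methyl, methoxy or trifluoromethyl in place of the chloro would hold the read-out level with compound 2 or shift it. Also open, on these data alone, is what a charged group such as an amine or a carboxylic acid on this ring would do, and whether the step from chloro to hydrogen keeps its size with other groups elsewhere on the shared core.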